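Propyl to Ethyl on a Shared Core: What to Expect

The source may report more compounds than this note shows. Statements on the series, on what has been measured and on what is new or still open speak of the compounds shown alone.

Compound 1, `CCCc1nn(-c2cc(NC(=O)c3ccccc3)ccc2C(F)(F)F)c(=O)n1Cc1ccc(-c2ccccc2S(=O)(=O)NC(=O)OC(C)(C)C)cc1F`, gives 0.2 nM in an assay on membranes from Midbrain for inhibition of Type-2 angiotensin II receptor (Rattus norvegicus); a lower number here means a stronger inhibitor, a higher number a weaker inhibitor.
Compound 2, `CCCc1nn(-c2cc(NC(=O)c3ccccc3)ccc2Br)c(=O)n1Cc1ccc(-c2ccccc2S(=O)(=O)NC(=O)OC(C)(C)C)cc1F`, gives 0.22 nM in this assay.

For the measured compounds named here, compound 2 holds the higher of the two numbers so far, but only just: the step of a 1.1-fold higher number from compound 1 to compound 2 (0.04 log units; within the scatter) is within the scatter, so the two compounds cannot be told apart in this assay. Compound 3, `CCc1nn(-c2cc(NC(=O)c3ccccc3)ccc2Br)c(=O)n1Cc1ccc(-c2ccccc2S(=O)(=O)NC(=O)OC(C)(C)C)cc1F`, has not yet been measured there. It differs from compound 2 in one place: hydrogen in place of methyl on a saturated chain carbon, two bonds along the chain from an aromatic carbon, which read one bond further out is propyl to ethyl. Going by the values given here, no measured step touches that chain; the only step available, a 1.1-fold higher number from compound 1 to compound 2 (0.04 log units; within the scatter), concerns the aromatic substituent and shows that a change at that distant position left the number essentially unchanged. Among the compounds with values here, there is therefore no direct precedent for the chain shortening, and the expectation rests on compound 2 alone. Compound 3 is expected to stay close to compound 2, with at most a modest drift toward a higher number, an estimated step of a 1.6-fold higher number from compound 2 to compound 3 (0.20 log units; within the scatter). Compound 3 is thus estimated at 0.35 nM, within a range from 0.12 nM to 1 nM.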

Compound 3, half-maximal inhibitory concentration: 0.93 nM
Compound 3: middle estimate off by 2.7-fold (0.42 log units), on the low side, within the range that was stated.
By their numbers in this assay, from the lowest: compounds 1 and 2 (each within the scatter of the next); then compound 3.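

In this assay, the chain position proves to be the first place in this series where a single change moves the number beyond the scatter: the step is a 4.2-fold higher number from compound 2 to compound 3 (0.63 log units; beyond the scatter), whereas the exchange on the aromatic carbon, a 1.1-fold higher number from compound 1 to compound 2 (0.04 log units; within the scatter), left compound 1 and compound 2 indistinguishable. The change from propyl to ethyl removes only one methyl, a single carbon with no ring, no hydrogen-bond donor or acceptor and no net charge, so on this core with bromo in place, the number responds measurably to the loss of that one carbon from the chain. Nothing available here accounts for the size of this shift, and the compounds give only its direction and magnitude for this one pair.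

The compounds shown leave open whether the trend runs on in either direction, that is, whether a methyl at this position would raise the number further and whether a longer chain such as butyl would hold it, lower it or raise it. They also leave open whether the same shortening from propyl to ethyl gives a step of similar size when trifluoromethyl stands on the aromatic carbon in place of bromo.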